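The source may hold more compounds than are shown below. What is called first, only, known or untested is meant among the compounds shown, and "the series" means these compounds.

Three compounds share one core and differ only in the group carried on the amide-type nitrogen of the side chain. Compound 1 `CCOC(=O)C1=C(C)NC(C)=C(C(=O)OCC)C1c1ccc(OCC(=O)Nc2c(C)cccc2C)cc1` gives 26.3% in a functional assay on the whole organism (strain Wistar) for inhibition, with Rattus norvegicus as the target, read by paw edema, with stated times of 30 min and 1 h, at a dose of 20 mg/kg; on this read-out higher numbers stand for more inhibition at the one dose given (going by the name of the read-out) and lower numbers for less inhibition. Compound 2 `CCOC(=O)C1=C(C)NC(C)=C(C(=O)OCC)C1c1ccc(OCC(=O)NNC(=O)c2ccc(C)cc2)cc1` gives 35.9%, and compound 3 `CCOC(=O)C1=C(C)NC(C)=C(C(=O)OCC)C1c1ccc(OCC(=O)NNC(=O)c2cccs2)cc1` gives 55.1%. Compound 3 stands highest of the three: the step of a number 28.8 percentage points higher from compound 1 to compound 3 (beyond the scatter) and the step of a number 19.2 percentage points higher from compound 2 to compound 3 (beyond the scatter) are both beyond the scatter, while the step of a number 9.6 percentage points higher from compound 1 to compound 2 (within the scatter) is within it. Compound 4 `CCOC(=O)C1=C(C)NC(C)=C(C(=O)OCC)C1c1ccc(OCC(=O)NNC(=O)CCC(=O)O)cc1` has not yet been measured; it differs from compound 3 in one place: 2-carboxyethyl in place of thiophen-2-yl on a carbonyl carbon. Going by the values given here, only one measured step alters the group on this carbonyl carbon, the one already named in which thiophen-2-yl replaced 4-methylphenyl, and it lay beyond the scatter. Among the compounds with values here, no measured compound carries 2-carboxyethyl at this place, so the direction cannot be read from the data. A step beyond the scatter is nonetheless expected, taken here as downward, estimated as a number 17.1 percentage points lower from compound 3 to compound 4 (beyond the scatter). Compound 4 is therefore expected to give about 38% in this assay, with a range from 22% to 55%.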

Compound 4, a percentage reported as inhibition, in the whole organism at one dose (the size of the read-out at that dose, not a potency): 43%
Beside the measured number, compound 4's estimate is 5 percentage points below it; the measured number falls inside the stated range.
By their numbers in this assay, from the lowest: compounds 1, 2 and 4 (each within the scatter of the next, the first and the last beyond it); then compound 3.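

Replacing the ringed thiophen-2-yl with 2-carboxyethyl, which has no ring and brings a hydrogen-bond donor, gives a number 12.1 percentage points lower from compound 3 to compound 4 (beyond the scatter) in this assay, so at this carbonyl carbon the choice of group can move the read-out in either direction. Against 4-methylphenyl, the same chain gives a number 7.1 percentage points higher from compound 2 to compound 4 (within the scatter) on this read-out, so among the groups shown here a ring is not needed to match compound 2. The full ((2-carboxyethyl)carbonyl)amino group, set against 2,6-dimethylphenyl on the amide-type nitrogen, gives a number 16.7 percentage points higher from compound 1 to compound 4 (beyond the scatter), so this open chain still keeps a gain over compound 1. The compounds shown leave open whether the carboxylic acid or the chain itself counts, as a butyl chain, a longer chain ending in a carboxylic acid, or a chain ending in an amine would help to tell. Nothing measured here explains these differences.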